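Hydroxy Replaced on the Carbonyl of Compound 1

The source may report more compounds than this note shows. Statements on the series, on what has been measured and on what is new or still open speak of the compounds shown alone.

Compound 1 `CCCC1=C(C(=O)OCc2ccc(C(=O)O)cc2)C(c2cccc(C)c2)NC(=O)N1` gives 3400 nM.
Compound 2 `COc1ccc(COC(=O)C2=C(C(C)C)NC(=O)NC2c2cccc(C)c2)cc1` gives 5800 nM.
Compound 3 `CCCC1=C(C(=O)OCC)C(c2cccc(Cl)c2)NC(=O)N1` gives 6800 nM.

These values come from a functional assay on HEK293 cells (Homo sapiens), read by cAMP accumulation; on this read-out lower numbers stand for an effect already at smaller amounts and higher numbers for an effect only at larger amounts of compound. Compound 1 has the lowest of the three numbers, yet its gaps to compound 2 and to compound 3 both lie within the scatter, so no order among the three can be claimed. Compound 4 `CCCC1=C(C(=O)OCc2ccc(C(=O)NCCCN3CCN(C)CC3)cc2)C(c2cccc(C)c2)NC(=O)N1` differs from compound 1 by (3-(4-methylpiperazin-1-yl)propyl)amino in place of hydroxy on a carbonyl carbon. Within the data shown here, no step between two measured compounds shows what such a change does in this assay, so the expectation rests on compound 1 alone. The estimate for compound 4 means a step of a 1.4-fold lower number from compound 1 to compound 4 (0.13 log units; within the scatter), expected to be small and within the scatter. Compound 4 is therefore expected to give 2500 nM, with a range from 700 nM to 9000 nM.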

Compound 4, half-maximal effective concentration: 4300 nM
Estimate against measurement, compound 4: 1.7-fold (0.24 log units) below; low and high end bracket the measured number.
By their numbers in this assay, from the lowest: compounds 1, 4, 2 and 3 (each within the scatter of the next).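

In this assay, among these compounds, the exchange of hydroxy for (3-(4-methylpiperazin-1-yl)propyl)amino on this carbonyl carbon gives a 1.3-fold higher number from compound 1 to compound 4 (0.10 log units; within the scatter) and is the first step read at this position. The much larger group, with its six-membered non-aromatic ring, leaves the number within the scatter of that of the carboxylic acid, compound 1. No measured evidence speaks to the reason for this. As far as these compounds go, it remains open whether the propyl chain or the piperazine ring matters here, and how a simple methylamide or a morpholine at the end of the same chain would read.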